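Shifting the Nitrile on the Indole of Compound 3

The source may hold more compounds than are shown below. What is called first, only, known or untested is meant among the compounds shown, and "the series" means these compounds.

Three compounds share a core in which a diphenylmethyl-piperazine carries a four-carbon chain ending in a bicyclic aromatic group. In an assay on RPMI-8226 cells for antagonist activity at P2X purinoceptor 7 (Homo sapiens), read by calcium flux (a higher number here means a weaker inhibitor, a lower number a stronger inhibitor), compound 1 `Cc1nc2ccccc2n1CCCCN1CCN(C(c2ccccc2)c2ccccc2)CC1` gives 850 nM, compound 2 `Cc1cc2ncn(CCCCN3CCN(C(c4ccccc4)c4ccccc4)CC3)c2cc1C` gives 770 nM, and compound 3 `N#Cc1cn(CCCCN2CCN(C(c3ccccc3)c3ccccc3)CC2)c2ccccc12` gives 1500 nM. Compound 3 has the largest of the three numbers, yet the steps of a 1.8-fold higher number from compound 1 to compound 3 (0.25 log units; within the scatter) and a 1.9-fold higher number from compound 2 to compound 3 (0.29 log units; within the scatter) both stay within the scatter, as does a 1.1-fold lower number from compound 1 to compound 2 (0.04 log units; within the scatter). Compound 4 `N#Cc1ccc2c(ccn2CCCCN2CCN(C(c3ccccc3)c3ccccc3)CC2)c1` differs from compound 3 only in where the nitrile sits: a group of 11 heavy atoms (9 carbon, 2 nitrogen; one five-membered aromatic ring with 1 hetero atom, one six-membered aromatic ring of carbon only) in place of a group of 11 heavy atoms (9 carbon, 2 nitrogen; one five-membered aromatic ring with 1 hetero atom, one six-membered aromatic ring of carbon only), on a saturated chain carbon, four bonds along the chain from an amine nitrogen in a ring. For the measured compounds named here, none of the measured steps moves a substituent around a ring in this way; they only exchange one bicyclic group for another, and all of them stayed within the scatter. On that basis no change beyond the scatter is expected, and the step of a 1.3-fold lower number from compound 3 to compound 4 (0.10 log units; within the scatter) is the estimate. In this assay compound 4 is therefore expected to give about 1200 nM, with a likely range from 500 nM to 3000 nM.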

Compound 4, half-maximal inhibitory concentration: 3800 nM
Compound 4: middle estimate off by 3.2-fold (0.50 log units), on the low side, and the stated range ends below it.
By their numbers in this assay, from the lowest: compounds 2, 1 and 3 (each within the scatter of the next); then compound 4.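

Moving the nitrile, with the same atoms joined differently, gives a 2.5-fold higher number from compound 3 to compound 4 (0.40 log units; beyond the scatter), the first step among these compounds to pass beyond the scatter, so the place of this one group on the bicyclic end of the chain matters and not only which atoms are present. The 5-cyano-1H-indol-1-yl group also stands apart from both benzimidazole groups, with a 4.9-fold higher number from compound 2 to compound 4 (0.69 log units; beyond the scatter) and a 4.5-fold higher number from compound 1 to compound 4 (0.65 log units; beyond the scatter), whereas the steps to compound 3 from those same two compounds stayed within the scatter. Nothing available explains why the nitrile's place makes this difference.

From the compounds shown here alone, only two places for the nitrile appear here, so how other places on the indole compare remains open. Also open, going by these compounds, is whether a carboxylic acid or an amide in place of the nitrile would respond to the same move, or whether a longer chain would alter the gap.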